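Methoxy to hydroxy on an inactive aryl amide

This account rests on a few compounds, and the source may have more. Where it says the series, first, only, none or still open, it means among the compounds named here.

In a functional assay on HL-60 cells (Homo sapiens) for inhibition, read by MTT assay, with a stated time of 72 h (a lower number here means a stronger inhibitor, a higher number a weaker inhibitor), only compound 1 `Cc1nc(-c2ccccc2Cl)c(C(=O)N2CCN(c3cccc(Cl)c3)CC2)o1` gives a number, at 132 nM with neither a methoxy nor a hydroxy group on its aromatic ring. Compound 2 `COc1ccc(-c2nc(C)oc2C(=O)N2CCN(c3cccc(Cl)c3)CC2)cc1O` is recorded as "not active" (no number reported) without a number. Compound 3 `COc1cccc(-c2nc(C)oc2C(=O)N2CCN(c3cccc(Cl)c3)CC2)c1` is likewise recorded as "not active" (no number reported) without a number. Compound 3 therefore has no place on a numeric scale: it stands with compound 2 among the entries lacking a single value, on the weak side of compound 1 as far as the record goes.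

The next compound to be read is compound 4 `Cc1nc(-c2cccc(O)c2)c(C(=O)N2CCN(c3cccc(Cl)c3)CC2)o1` in this assay as well. The structural change is hydrogen in place of methyl on an oxygen on an aromatic ring and amounts to hydrogen in place of methyl on an oxygen on an aromatic ring, that is, 3-methoxyphenyl to 3-hydroxyphenyl. Within the data shown here, no measured step shows what this exchange does. Compound 2 already holds a hydroxy group on an aromatic ring and is still recorded as "not active" (no number reported) in this series, so only a modest move toward stronger inhibition is expected, and a result without a number remains more likely than not. Should a number appear, the estimated value for compound 4 is 2000 nM within an expected range from 300 nM to 15000 nM as a working figure.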

Compound 4, half-maximal inhibitory concentration: 105 nM
Compound 4: the middle estimate sits 19-fold (1.28 log units) above what was measured; measured number below the stated range.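

In this assay the change from 3-methoxyphenyl to 3-hydroxyphenyl separates compound 3, recorded as not active, from compound 4 at 105 nM and thus shows that a number can be obtained with a substituent at this place, although no step can be read for this pair without a number for compound 3. Among these compounds, the one readable step is a 1.3-fold lower number from compound 1 to compound 4 (0.10 log units; within the scatter) and it places 3-hydroxyphenyl in place of 2-chlorophenyl inside the scatter, so these two aryl groups cannot be told apart in this assay on these data. No measurement shown explains why removing the methyl from the oxygen turns an entry without a number into one with a number.

The hydroxy group does not give a number in every case: compound 2 also carries one, together with a methoxy group on the same ring, and remains recorded as not active, and the compounds shown do not settle how the second group bears on that outcome. Also open, from the compounds shown here alone, is whether an amino group or a carboxylic acid in place of the hydroxy group would keep a number in this range.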